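Notes on a cinnamate ester series with weak cytotoxicity

A few compounds are considered here, and "the series" means these few. Any claim that something is new, unique, unknown or untested is made for them only; others in the source may bear on it.

The compounds are tested in a functional assay on HeLa cells (Homo sapiens) for cytotoxicity, read by MTT assay, with a stated time of 72 h; on this read-out higher numbers stand for weaker inhibition and lower numbers for stronger inhibition. Compound 1 `COc1ccc(/C=C/C(=O)OCC(=O)Nc2ccccc2)cc1OC` gives 193000 nM in this assay. Compound 3 `O=C(COC(=O)/C=C/c1ccc(O)c(O)c1)Nc1ccc(Cl)cc1` gives 195000 nM in this assay and so stands level with compound 1, the two values within the scatter of each other. Compound 2 `CCOc1ccc(COc2c(OC)cc(/C=C/C(=O)N3CCN(Cc4ccc(Cl)c(Cl)c4)CC3)cc2OC)cc1` reaches only the limit of this assay, > 200000 nM. This is the limit of > 200000 nM in this assay, at which 1 of the 3 values shown sits. Compound 4 `O=C(COC(=O)/C=C/c1ccc(O)c(O)c1)NN1CCOCC1` has not yet been measured. It differs from compound 3 by morpholin-4-yl in place of 4-chlorophenyl on an amide-type nitrogen. Going by the values given here, no measured pair shows the effect of such a change, and every number so far sits at the weak end of this assay. The expected step is a 1.0-fold higher number from compound 3 to compound 4 (0.01 log units; within the scatter), no larger than the scatter. Compound 4 is estimated at 200000 nM, with a range from 100000 nM to 400000 nM.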

Compound 4, half-maximal inhibitory concentration: > 200000 nM
Compound 4 gave a limit, no number; the forecaster's own chance of this, stated with the estimate: 50%; the middle value sits exactly at the limit.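

Morpholin-4-yl in place of 4-chlorophenyl on an amide-type nitrogen now has a first reading in this assay: an at least 1.0-fold higher number from compound 3 to compound 4 (0.01 log units; that floor lies within the scatter). Compound 4 gives > 200000 nM, which is a limit and not a number, so this step is only a floor and the change brings no gain in inhibition. Compound 4 now shares one reading with compound 2: the limit of > 200000 nM in this assay, at which 2 of the 4 values shown sit.

From the compounds shown here alone, the true size of the step stays open. Also open, going by these compounds, is whether a carboxylic acid or a dimethylamino group at this place would give a readable number in this assay.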